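Cinnamoyl Amide Replacing Fluorobenzoyl on a Bis-indole Core

The source may report more compounds than this note shows. Statements on the series, on what has been measured and on what is new or still open speak of the compounds shown alone.

Measured compounds:
Compound 1 `CN1[C@@H]2c3[nH]c4ccccc4c3C[C@H]1[C@H](C#N)N1[C@@H](CNC(=O)c3ccc(F)cc3)c3[nH]c4ccccc4c3C[C@@H]21` — 140 nM
Compound 2 `CN1[C@@H]2c3[nH]c4ccccc4c3C[C@H]1[C@H](C#N)N1[C@@H](CNC(=O)c3ccc4ccccc4n3)c3[nH]c4ccccc4c3C[C@@H]21` — 240 nM
Compound 3 `CN1[C@@H]2c3[nH]c4ccccc4c3C[C@H]1[C@H](C#N)N1[C@@H](CNC(=O)/C=C/c3cccc(C(F)(F)F)c3)c3[nH]c4ccccc4c3C[C@@H]21` — 610 nM

In a functional assay on HCT-116 cells (Homo sapiens) for cytotoxicity, read by MTT assay, with a stated time of 72 h (a higher number here means a weaker inhibitor, a lower number a stronger inhibitor), compound 1 stands at the low end of the three numbers. Its step to compound 2 a 1.7-fold higher number from compound 1 to compound 2 (0.23 log units; within the scatter) is within the scatter, whereas a 4.4-fold higher number from compound 1 to compound 3 (0.64 log units; beyond the scatter) and a 2.5-fold higher number from compound 2 to compound 3 (0.41 log units; beyond the scatter) are beyond it.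

Compound 4 `COc1ccc(/C=C/C(=O)NC[C@H]2c3[nH]c4ccccc4c3C[C@H]3[C@H]4c5[nH]c6ccccc6c5C[C@@H]([C@H](C#N)N23)N4C)cc1` has not been measured. It differs from compound 1 in one place: 2-(4-methoxyphenyl)ethenyl in place of 4-fluorophenyl on a carbonyl carbon

The step that bears on this change is a 4.4-fold higher number from compound 1 to compound 3 (0.64 log units; beyond the scatter), where another 2-arylethenyl group replaced the same 4-fluorophenyl on the carbonyl carbon. A similar modest rise in number is therefore expected for compound 4, a 3.2-fold higher number from compound 1 to compound 4 (0.51 log units; beyond the scatter), giving an estimated 450 nM with a range from 200 nM to 1200 nM.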

Compound 4, half-maximal inhibitory concentration: 5060 nM
The estimate for compound 4 lay 11-fold (1.05 log units) below the measured number; the whole stated range lies below it.
By their numbers in this assay, from the lowest: compounds 1 and 2 (each within the scatter of the next); then compound 3; then compound 4.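

In this assay, the aryl group on the double-bonded chain carbon matters as well as the ethenyl chain: 4-methoxyphenyl in place of 3-(trifluoromethyl)phenyl gives an 8.3-fold higher number from compound 3 to compound 4 (0.92 log units; beyond the scatter). Against the earlier aryl groups on the carbonyl carbon, the change gives a 36-fold higher number from compound 1 to compound 4 (1.56 log units; beyond the scatter) and a 21-fold higher number from compound 2 to compound 4 (1.32 log units; beyond the scatter), which sets compound 4 apart from all three earlier compounds. Nothing available explains this rise.

As far as these compounds go, it remains open how a plain phenyl, or an amine or a carboxylic acid on that phenyl ring, would read on the same ethenyl chain.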